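This account rests on a few compounds, and the source may have more. Where it says the series, first, only, none or still open, it means among the compounds named here.

Series notes. Compound 1 `Cn1ccc2c(Oc3ccc(NC(=O)c4cn(-c5ccccc5)c5ccccc5c4=O)cc3F)ccnc21` and compound 2 `Cn1ccc2c(Oc3ccc(NC(=O)c4cn(-c5ccc(Br)cc5)c5ccccc5c4=O)cc3F)ccnc21` share one core and differ only at the phenyl on the ring nitrogen. In a functional assay on A549 cells (Homo sapiens) for inhibition, read by MTT assay, with a stated time of 72 h (on this read-out lower numbers stand for stronger inhibition and higher numbers for weaker inhibition), compound 1 gives 1720 nM, and in this assay compound 2 gives 1390 nM. Among the compounds with values here, the single measured step, a 1.2-fold lower number from compound 1 to compound 2 (0.09 log units; within the scatter), does not separate the two compounds. Compound 2 therefore stands at the lowest of the two numbers, with compound 1 beside it within the scatter; no order between them can be claimed on these data.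

Compound 3 `Cn1ccc2c(Oc3ccc(NC(=O)c4cn(-c5ccc(Br)cc5F)c5ccccc5c4=O)cc3F)ccnc21` is the next member, not yet measured in this assay. It differs from compound 2 as follows: fluoro in place of hydrogen on an aromatic carbon. Within the data shown here, no measured step concerns a fluoro at this place; the only step available is that from hydrogen to bromo on the same ring, a 1.2-fold lower number from compound 1 to compound 2 (0.09 log units; within the scatter), which stayed within the scatter. On that basis the step of a 1.1-fold lower number from compound 2 to compound 3 (0.03 log units; within the scatter) is expected to be small, with no direction beyond the scatter. Compound 3 is estimated to give 1300 nM in this assay, within a range of 600 nM to 2800 nM.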

Compound 3, half-maximal inhibitory concentration: 1520 nM
Beside the measured number, compound 3's estimate is 1.2-fold (0.07 log units) below it; the measured number falls inside the stated range.
By their numbers in this assay, from the lowest: compounds 2, 3 and 1 (each within the scatter of the next).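

In this assay, within the data shown here, fluoro in place of hydrogen, on the aromatic carbon ortho to a large group and meta to the bromo group, gives a 1.1-fold higher number from compound 2 to compound 3 (0.04 log units; within the scatter), the first reading of a fluoro at this place, and the step stays within the scatter. Read against the unsubstituted phenyl, 4-bromo-2-fluorophenyl in place of phenyl gives a 1.1-fold lower number from compound 1 to compound 3 (0.05 log units; within the scatter), so the two ring substituents together also stay within the scatter, which the single bromo step could not show. No evidence is at hand that bears on this result.

On these data alone, whether any group on this phenyl can move the number beyond the scatter stays open: the three compounds carry only hydrogen, bromo and fluoro on it, and an amine, a carboxylic acid or a longer chain on the same ring would put that to the test. Also open, as far as these compounds go, is whether the shared core, outside this phenyl, holds a place where one change reaches beyond the scatter.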